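Swapping the ring on the pyrrolidine nitrogen: what to expect

A few compounds are considered here, and "the series" means these few. Any claim that something is new, unique, unknown or untested is made for them only; others in the source may bear on it.

Measured so far in a functional assay for antagonist activity at transient receptor potential cation channel subfamily V member 1 (Rattus norvegicus), read by FLIPR; a higher number here means a more potent compound, by a factor of ten per unit of this negative logarithm, a lower number a less potent compound:
- Compound 1 `O=C(Nc1ccccc1Br)N[C@@H]1CCN(c2ccccn2)C1`: in this assay compound 1 gives < 6.6, which is a limit of the assay, not a number.
- Compound 2 `O=C(Nc1ccccc1Br)N[C@@H]1CCN(c2ccc(F)c(F)c2)C1`: in this assay compound 2 gives 8.1.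
- Compound 3 `Cc1cccc(N2CC[C@@H](NC(=O)Nc3ccccc3Br)C2)c1`: in this assay compound 3 gives 7.7.

Among the measured compounds shown here, compound 3 sits lowest of the two numbers known, with compound 2 nearest; the step of a number 0.40 log units lower from compound 2 to compound 3 (beyond the scatter) puts it beyond the scatter. Compound 1 only marks a limit (the limit of < 6.6 in this assay, at which 1 of the 3 values shown sits).

Compound 4 `O=C(Nc1ccccc1Br)N[C@@H]1CCN(c2ccc(Cl)cn2)C1` carries the change (5-chloropyridin-2-yl in place of 3-methylphenyl on an amine nitrogen in a ring). For the measured compounds named here, the steps that bear on it both involve the ring on that nitrogen: a number at least 1.10 log units higher from compound 1 to compound 3 (beyond the scatter), a large gain when a pyridin-2-yl gives way to 3-methylphenyl, and a number 0.40 log units lower from compound 2 to compound 3 (beyond the scatter), a modest loss when halogens give way to a methyl. Compound 4 brings back a pyridin-2-yl, now bearing a chlorine, so a drop in this assay is expected, softened somewhat by the chlorine, the step being estimated at a number 0.80 log units lower from compound 3 to compound 4 (beyond the scatter). Compound 4 is therefore expected to give about 6.9, within 6.1 to 7.7.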

Compound 4, negative logarithm of the antagonist equilibrium constant: 7.3
The estimate for compound 4 lay 0.40 log units below the measured number; measured number inside the range.
By their numbers in this assay, from the lowest: compound 4; then compound 3; then compound 2. At a limit, below all of these: compound 1.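

In this assay, chloro in place of hydrogen on an aromatic carbon of the pyridin-2-yl ring brings a clear gain, with a number at least 0.70 log units higher from compound 1 to compound 4 (beyond the scatter). That step can be read only as a bound, since compound 1 stands at a limit and not at a number: the limit of < 6.6 in this assay, at which 1 of the 4 values shown sits. The 5-chloropyridin-2-yl group still trails the two rings of carbon only, with a number 0.40 log units lower from compound 3 to compound 4 (beyond the scatter) and a number 0.80 log units lower from compound 2 to compound 4 (beyond the scatter), so on this amine nitrogen it is tolerated but matches neither 3-methylphenyl nor 3,4-difluorophenyl.

Going by these compounds, it remains open whether a 5-methylpyridin-2-yl or 5-methoxypyridin-2-yl group would give a similar gain to the 5-chloropyridin-2-yl group. Also open, on these data alone, is how a 4-chlorophenyl group would compare with the 5-chloropyridin-2-yl group at this position.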